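A few compounds are considered here, and "the series" means these few. Any claim that something is new, unique, unknown or untested is made for them only; others in the source may bear on it.

Measured so far in an assay on isolated protein for inhibition of 2-Hydroxyacid oxidase 2 (Homo sapiens), tested at 1 uM; on this read-out lower numbers stand for a weaker effect and higher numbers for a stronger effect at the one concentration tested:

Compound 1, `Cc1n[nH]c(C(=O)O)c1Cc1ccccc1-c1ccc(F)cc1`, gives 11%.
Compound 2, `Cc1n[nH]c(C(=O)O)c1Cc1cccc(-c2ccccc2F)c1`, gives 5%.
Compound 3, `Cc1n[nH]c(C(=O)NS(C)(=O)=O)c1Cc1cccc(-c2ccc(F)cc2)c1`, gives 8%.

All three share the same core and differ in the group hung on it and in the acid end. Compound 2 stands at the low end of these three numbers, yet the gap to compound 3 and the gap to compound 1 each lie within the usual scatter of this assay, so the three read as one level of weak effect rather than as a ranking.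

The next compound, compound 4, `Cc1n[nH]c(C(=O)O)c1Cc1cccc(OC(F)(F)F)c1`, differs from compound 2 in one place: trifluoromethoxy in place of 2-fluorophenyl on an aromatic carbon. Going by the values given here, no pair among the measured compounds tells what a change of this kind does here, so the expectation rests on the level the three measured compounds set.

Because compound 2 gives 5% and the others sit in the same narrow band, the step from compound 2 to compound 4 is expected to be small, a number 3 percentage points higher from compound 2 to compound 4 (within the scatter), with no direction beyond the scatter. Compound 4 is therefore estimated at 8% in this assay, within a range from 0% to 18%.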

Compound 4, a percentage reported as inhibition, at one concentration (the size of the read-out at that concentration, not a potency): 2%
Compound 4: the middle estimate sits 6 percentage points above what was measured, and the stated range covers the measured number.
By their numbers in this assay, from the lowest: compounds 4, 2, 3 and 1 (each within the scatter of the next).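

In this assay, going by these compounds alone, the replacement of 2-fluorophenyl by trifluoromethoxy on this aromatic carbon, meta to a large group, gives the first single-change step (a number 3 percentage points lower from compound 2 to compound 4 (within the scatter)), and that step lies within the scatter. The change takes away a whole six-membered aromatic ring and puts a ringless group with one hydrogen-bond acceptor in its place, yet the read-out shows no change that can be told apart from repeat scatter. So at the one concentration tested, this pair gives no sign that the aromatic ring at this position matters, although a read-out this low may have little room to show a loss. No measured evidence bears on this result, and it offers no explanation for it.

The four compounds, each within the scatter of the next, leave open whether any group on this carbon can lift the read-out clearly beyond that scatter. A basic amine, a carboxylic acid or a longer alkyl chain here could test that, and each would give a second single-change step to compare with this one.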